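The compounds below may be only part of what the source reports. "The series", "measured", "known", "first", "only" and "open" are said of these compounds alone.

Measured so far:
- compound 1 `COc1cc2c(Oc3ccc(NC(=O)c4nnn(-c5ccccc5)c4C)cc3F)ccnc2cc1OCCCN1CCCC1`: in a functional assay on U-87MG ATCC cells (Homo sapiens) for cytotoxicity, read by MTT assay, with a stated time of 72 h (on this read-out higher numbers stand for weaker inhibition and lower numbers for stronger inhibition), compound 1 gives 1000 nM.
- compound 2 `COc1cc2c(Oc3ccc(NC(=O)c4nnn(-c5ccc(F)cc5)c4C(F)(F)F)cc3F)ccnc2cc1OCCCN1CCCC1`: in this assay compound 2 gives 850 nM.

Compound 2 shows the lower of the two numbers, but compound 1 sits within the scatter of it, so no order between the two can be read. Compound 3 `COc1cc2c(Oc3ccc(NC(=O)c4nnn(-c5ccccc5C(F)(F)F)c4C(F)(F)F)cc3F)ccnc2cc1OCCCN1CCCC1` is still to be measured in this assay. It differs from compound 2 in one place: 2-(trifluoromethyl)phenyl in place of 4-fluorophenyl on an aromatic nitrogen. For the measured compounds named here, no step between measured compounds covers a change of this kind, so nothing beyond the scatter is expected in this assay in either direction. The expected step is a 1.1-fold higher number from compound 2 to compound 3 (0.02 log units; within the scatter). For compound 3 the expected value is 900 nM, range 350 nM to 2500 nM.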

Compound 3, half-maximal inhibitory concentration: 1180 nM
For compound 3 the middle estimate is 1.3-fold (0.12 log units) below the measured one; low and high end bracket the measured number.
By their numbers in this assay, from the lowest: compounds 2, 1 and 3 (each within the scatter of the next).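

Replacing 4-fluorophenyl with 2-(trifluoromethyl)phenyl on the aromatic nitrogen gives a 1.4-fold higher number from compound 2 to compound 3 (0.14 log units; within the scatter) in this assay for this change. This position therefore accepts a group of 10 heavy atoms in place of one of 7 with no change that can be read. No data at hand bear on the reason for this result.

On these data alone, whether an amine or a carboxylic acid on this phenyl ring would move the number beyond the scatter remains open. Compound 1 and compound 2 differ in more than one place, so the trifluoromethyl group on the five-membered ring cannot be assessed separately.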